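This account rests on a few compounds, and the source may have more. Where it says the series, first, only, none or still open, it means among the compounds named here.

Three compounds have been measured in a functional assay on THP-1 cells (Homo sapiens) for inhibition, read by sulforhodamine B assay, with a stated time of 48 h, tested at 50 uM; on this read-out higher numbers stand for more inhibition of growth at the one concentration tested and lower numbers for less inhibition of growth:

Compound 1 `COc1cc(/C=C/C(=O)/C=C/c2cc(OC)c(OC)c(OC)c2)ccc1OCc1cn(CCOc2cc(=O)oc3ccccc23)nn1`, which in this assay gives 99%.
Compound 2 `COc1cc(/C=C/C(=O)/C=C/c2ccccc2)ccc1OCc1cn(CCCCCOc2cc(=O)oc3ccccc23)nn1`, which in this assay gives 26%.
Compound 3 `COc1cc(/C=C/C(=O)/C=C/c2ccccc2)ccc1OCc1cn(CCOc2cc(=O)oc3ccccc23)nn1`, which in this assay gives 61%.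

Compound 2 gives the lowest of the three numbers, and its gaps to both other compounds lie beyond the usual scatter. Compound 3 and compound 1 share one core and differ in a single place: 3,4,5-trimethoxyphenyl in place of phenyl on a double-bonded chain carbon bound to a double-bonded chain carbon. This change produced a number 38 percentage points higher from compound 3 to compound 1 (beyond the scatter), a large step. Compound 1 already stands close to complete inhibition of growth at the tested concentration, so this step may understate what the change would give from a lower starting point.

Compound 4 `COc1cc(/C=C/C(=O)/C=C/c2cc(OC)c(OC)c(OC)c2)ccc1OCc1cn(CCCCCOc2cc(=O)oc3ccccc23)nn1` has not yet been measured. It stands to compound 2 as compound 1 stands to compound 3: the change is 3,4,5-trimethoxyphenyl in place of phenyl on a double-bonded chain carbon bound to a double-bonded chain carbon, at the same place as before, so it is the same change. The core of compound 2 and the core of compound 3 are not the same, and the difference between the two cores is not broken down here.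

Given that the same change lifted compound 3 to compound 1 by a number 38 percentage points higher from compound 3 to compound 1 (beyond the scatter), a step of similar size is expected from compound 2 to compound 4, namely a number 36 percentage points higher from compound 2 to compound 4 (beyond the scatter), while the single example and the different core leave the expectation loose. In this assay compound 4 is estimated at 62%, between 38% and 85%.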

Compound 4, percent growth inhibition at one concentration: 55%
Beside the measured number, compound 4's estimate is 7 percentage points above it; measured number inside the range.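

Putting 3,4,5-trimethoxyphenyl in place of phenyl on a double-bonded chain carbon bound to a double-bonded chain carbon also raised the number in this assay on the core of compound 2, giving a number 29 percentage points higher from compound 2 to compound 4 (beyond the scatter). Set beside the earlier case, the change carried over from one core to the other with a step of matching size: the same change on two cores in this assay, a number 38 percentage points higher (beyond the scatter) from compound 3 to compound 1 and a number 29 percentage points higher (beyond the scatter) from compound 2 to compound 4, 9 percentage points apart, within the scatter of two such steps This shows that, in this small series, the gain from the change did not depend on which of these two cores carried it, but two cores are too few to predict a third, and the data do not explain why the change raises the number.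

The compounds shown leave open which part of the 3,4,5-trimethoxyphenyl group matters, since a phenyl carrying a single methoxy group, or one carrying an amine or a carboxylic acid, would test whether the full group is needed. They also leave open whether the same gain would appear on a core with a longer chain, and how the compounds compare at lower concentrations, given that each was tested at just one.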